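Carboxy for methanesulfonamido on a piperidine-bearing core

The source may hold more compounds than are shown below. What is called first, only, known or untested is meant among the compounds shown, and "the series" means these compounds.

The measured compounds:
Compound 1, `NC(=O)N1CCN(C2CN(CCC3(c4ccc(Cl)c(Cl)c4)CCC(=O)N(CC4CC4)C3)C2)CC1`, gives 5.01 nM in an assay on isolated protein (artery, Oryctolagus cuniculus) with Substance-P receptor (Homo sapiens) as the target; a lower number here means tighter binding, a higher number weaker binding.
Compound 2, `NC1CCN(C2CN(CCC3(c4ccc(Cl)c(Cl)c4)CCC(=O)N(CC4CC4)C3)C2)CC1`, gives 2 nM in this assay.
Compound 3, `CS(=O)(=O)NC1CCN(C2CN(CCC3(c4ccc(Cl)c(Cl)c4)CCC(=O)N(CC4CC4)C3)C2)CC1`, gives 10 nM in this assay.

Compound 3 has the highest number of the three, meaning the weakest binding. Its gap to compound 1 is within the scatter, so the two cannot be told apart; its gap to compound 2 is beyond the scatter, shown by a 5.0-fold higher number from compound 2 to compound 3 (0.70 log units; beyond the scatter).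

Compound 4, `O=C(O)C1CCN(C2CN(CCC3(c4ccc(Cl)c(Cl)c4)CCC(=O)N(CC4CC4)C3)C2)CC1`, differs from compound 3 by carboxy in place of methanesulfonamido on a saturated ring carbon. Within the data shown here, no measured step exchanges these two groups, so the forecast rests on how much the group on this ring carbon has mattered so far: a 2.5-fold lower number from compound 1 to compound 2 (0.40 log units; beyond the scatter) and a 2.0-fold higher number from compound 1 to compound 3 (0.30 log units; within the scatter) were both modest or within the scatter. Compound 4 is therefore expected to stay in the same neighbourhood, with a 1.2-fold higher number from compound 3 to compound 4 (0.08 log units; within the scatter) as a small step whose direction is uncertain.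

Compound 4 is estimated to give 12 nM in this assay, between 3 nM and 40 nM.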

Compound 4, dissociation constant: 0.398 nM
Compound 4: middle estimate off by 30-fold (1.48 log units), on the high side; measured number outside the range, below it.
By their numbers in this assay, from the lowest: compound 4; then compound 2; then compounds 1 and 3 (each within the scatter of the next).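

On this saturated ring carbon, carboxy gives the tightest binding of the four compounds in this assay, and its advantage over each of the other groups lies beyond the scatter: against methanesulfonamido (a 25-fold lower number from compound 3 to compound 4 (1.40 log units; beyond the scatter)), against the 4-carbamoylpiperazin-1-yl group (a 13-fold lower number from compound 1 to compound 4 (1.10 log units; beyond the scatter)), and against amino (a 5.0-fold lower number from compound 2 to compound 4 (0.70 log units; beyond the scatter)). Until now the changes at this place had produced only modest steps or ones within the scatter, so it could have passed as a position that tolerates many groups; the two large steps show that the choice of group here can shift binding much further, while the shared core stays unchanged. Nothing available here explains why carboxy has this effect.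

On these data alone, it remains open whether the tight binding depends on the free carboxylic acid itself, or would also appear with its methyl ester, a primary amide or a tetrazole in the same place. A longer chain, such as carboxymethyl on the same ring carbon, would show whether the distance of the acid from the ring matters as well.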